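Methyl for isopropyl on the sulfonamide-bearing chain carbon

The source may report more compounds than this note shows. Statements on the series, on what has been measured and on what is new or still open speak of the compounds shown alone.

Measured compounds:
- compound 1, `CC(C)C(NS(=O)(=O)c1ccc(Cl)cc1)C1=CC(=O)c2c(O)ccc(O)c2C1=O`: "not determined" (no result reported)
- compound 2, `CCOC(=O)c1ccc(S(=O)(=O)NC(C2=CC(=O)c3c(O)ccc(O)c3C2=O)C(C)C)cc1`: 150 nM

Compound 1 has no number in a functional assay on HL-60 cells (Homo sapiens) for cytotoxicity, read by MTT assay; on this read-out lower numbers stand for stronger inhibition and higher numbers for weaker inhibition; it therefore stands nowhere on the scale, and the only anchor in the series is compound 2, which in this assay gives 150 nM. Compound 2 keeps the isopropyl group and the shared core of compound 1 and differs from it only in the substituent on the sulfonyl aryl ring, so it is the closest measured reference for the chain.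

Compound 3, `CC(NS(=O)(=O)c1ccc(Cl)cc1)C1=CC(=O)c2c(O)ccc(O)c2C1=O`, is the next analog. Relative to compound 1 it carries methyl in place of isopropyl on a saturated chain carbon bound to a double-bonded ring carbon and a sulfonamide nitrogen. Among the measured compounds shown here, no measured pair shows the effect of this change, so its size is open; the expectation is a step in this assay that stays within the usual scatter or leans toward somewhat weaker inhibition, since the smaller chain gives no obvious ground to expect a gain.

With that reasoning, and anchored on compound 2 at 150 nM, compound 3 is estimated at 300 nM in this assay, with a plausible range from 80 nM to 1500 nM.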

Compound 3, half-maximal inhibitory concentration: 250 nM
The estimate for compound 3 lay 1.2-fold (0.08 log units) above the measured number; the range from low to high includes it.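

Compound 1 has no single number in this assay, and the step from it to compound 3 cannot be read. The compounds shown leave open what methyl in place of isopropyl does on the saturated chain carbon bound to a double-bonded ring carbon and a sulfonamide nitrogen. No further evidence bears on this result.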